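Anilino analogue of the ethylphenyl lead: removing the para ethyl

A few compounds are considered here, and "the series" means these few. Any claim that something is new, unique, unknown or untested is made for them only; others in the source may bear on it.

Compound 1 `CCc1ccc(NC2=CC(=O)c3nc4n(c3C2=O)[C@H]2OC[C@@H](O)[C@H]2OC4)cc1` carries a (4-ethylphenyl)amino group on the shared core. In a functional assay on ECa-109 cells for inhibition, with ECa-109 cell line (Homo sapiens) as the target, read by sulforhodamine B assay (a higher number here means a weaker inhibitor, a lower number a stronger inhibitor), compound 1 gives 3080 nM, the lowest of the two numbers available. The nearest comparator is compound 3 `COc1cccc(NC2=CC(=O)c3c(nc4n3[C@H]3OC[C@@H](O)[C@H]3OC4)C2=O)c1`, which in this assay gives 3340 nM; the gap to compound 1 lies within the usual scatter, so the two cannot be ordered. Compound 2 `O=C1C(N2CCC2)=CC(=O)c2c1nc1n2[C@H]2OC[C@@H](O)[C@H]2OC1` reaches only a limit of this assay, > 16000 nM, not a number. That limit is the one at which one of the three values sits (the limit of > 16000 nM in this assay, at which 1 of the 3 values shown sits). The step of an at least 4.7-fold lower number from compound 2 to compound 3 (0.68 log units; beyond the scatter) shows how much an arylamino group on the double-bonded ring carbon gains over azetidin-1-yl, but it says nothing about substituents on the aryl ring.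

Compound 4 `O=C1C=C(Nc2ccccc2)C(=O)c2c1nc1n2[C@H]2OC[C@@H](O)[C@H]2OC1` differs from compound 1 by hydrogen in place of ethyl on an aromatic carbon, on the aromatic carbon para to a large group. Among the measured compounds shown here, no measured step alters a substituent on that aryl ring. For the measured compounds named here, the only hint is that compound 1 and compound 3, with different aryl substituents, sit within scatter of each other. The step of a 1.2-fold higher number from compound 1 to compound 4 (0.07 log units; within the scatter) is therefore expected to be small, with no clear direction beyond the scatter. Compound 4 is estimated at 3600 nM, with a range of 1500 nM to 9000 nM.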

Compound 4, half-maximal inhibitory concentration: 4970 nM
Compound 4: middle estimate off by 1.4-fold (0.14 log units), on the low side; low and high end bracket the measured number.
By their numbers in this assay, from the lowest: compounds 1, 3 and 4 (each within the scatter of the next). At a limit, above all of these: compound 2.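

Among the compounds shown here, removing ethyl from the aromatic carbon para to a large group gives the first measured change on this aryl ring, and in this assay the step of a 1.6-fold higher number from compound 1 to compound 4 (0.21 log units; within the scatter) leaves 4-ethylphenyl and phenyl indistinguishable at this position. Ethyl is therefore not required for the activity level seen with compound 1, and the unsubstituted anilino group of compound 4 serves as a reference for this aryl ring within the compounds shown. For the compounds shown here, nothing available bears on the reason for this step, as the only supporting information concerns the limit reached with a different group on the shared core.

On these data alone, only hydrogen and ethyl have been compared at this aromatic carbon, so it remains open whether a carboxylic acid, a primary amine or a longer chain such as hexyl would shift the number beyond the scatter. Also open, as far as these compounds go, is whether a larger saturated amine such as morpholine on the double-bonded ring carbon would behave like azetidin-1-yl or like the arylamino groups.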